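The compounds below may be only part of what the source reports. "The series", "measured", "known", "first", "only" and "open" are said of these compounds alone.

Of the compounds shown here, three built on one shared core have been tested in a functional assay on the whole organism with Rattus norvegicus as the target; on this read-out lower numbers stand for an effect already at smaller amounts and higher numbers for an effect only at larger amounts of compound. Compound 1 `CCCCc1c(OC)nc2nc(C(=O)c3ccccc3)cn2c1C` gives 2 mg/kg. Compound 2 `C=CCc1c(OC)nc2nc(C(=O)c3ccccc3)cn2c1C` gives 5 mg/kg, and compound 3 `COc1cc(C)n2cc(C(=O)c3ccccc3)nc2n1` gives 5 mg/kg. Compound 3 stands level with compound 2 at the digits printed, and together they carry the highest numbers of the three; the only gap beyond the scatter is a 2.5-fold higher number from compound 1 to compound 3 (0.40 log units; beyond the scatter).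

Compound 4 `COc1nc2nc(C(=O)c3ccccc3)cn2c(C)c1OC` has not yet been measured. It differs from compound 3 in one place: methoxy in place of hydrogen on an aromatic carbon.

Among the compounds with values here, no measured step adds a group at this position; the two that touch it run the other way. When butyl was removed there, a 2.5-fold higher number from compound 1 to compound 3 (0.40 log units; beyond the scatter), the number rose modestly, while when allyl was removed, no change at the digits printed from compound 2 to compound 3 (within the scatter), the number held. Butyl thus helped, allyl did not beyond the scatter, and methoxy matches neither chain. Compound 4 is therefore expected to stay close to compound 3, with at most a small fall in the number, no change at the digits printed from compound 3 to compound 4 (within the scatter). The estimate for compound 4 in this assay is 5 mg/kg, within a range from 2 mg/kg to 12 mg/kg.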

Compound 4, minimum effective dose: 5 mg/kg
For compound 4 middle estimate and measured number coincide at the digits printed; measured number inside the range.
By their numbers in this assay, from the lowest: compound 1; then compounds 2, 3 and 4 (each within the scatter of the next).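

In this assay, within the data shown here, this is the first step at this position that adds a group to the aromatic carbon instead of removing one, and placing methoxy there in place of hydrogen leaves the reading flat (no change at the digits printed from compound 3 to compound 4 (within the scatter)). Methoxy and allyl also cannot be told apart at this site (no change at the digits printed from compound 2 to compound 4 (within the scatter)), while butyl still separates from methoxy (a 2.5-fold higher number from compound 1 to compound 4 (0.40 log units; beyond the scatter)), so that among hydrogen, methoxy, allyl and butyl, only butyl in compound 1 stands apart, with the lowest number. Nothing measured here explains what sets butyl apart from the other three groups.

From the compounds shown here alone, it remains open whether a saturated chain shorter than butyl, such as ethyl or propyl, or a longer one, such as hexyl, would read like butyl or like the other three groups. Going by these compounds, the reading of a different kind of group at this position, such as an amine or a carboxylic acid, also remains open, as does whether a lower number could be reached with a ring such as phenyl in that place.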